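The source may report more compounds than this note shows. Statements on the series, on what has been measured and on what is new or still open speak of the compounds shown alone.

Measured so far in a functional assay on SK-MEL-5 cells (Homo sapiens) for antiproliferative activity, read by sulforhodamine B assay, with a stated time of 48 h; a higher number here means a weaker inhibitor, a lower number a stronger inhibitor:
compound 1 `COc1cc(-c2nn(-c3ccc(NC(=O)Nc4ccc(Cl)c(Cl)c4)cc3)cc2-c2ccncc2)ccc1Cl` — 2840 nM
compound 2 `COc1cc(-c2nn(-c3ccc(NC(=O)c4ccc(Cl)c(Cl)c4)cc3)cc2-c2ccncc2)ccc1Cl` — 1650 nM

Compound 2 has the lowest of the two numbers; its nearest neighbour is compound 1, and the step of a 1.7-fold lower number from compound 1 to compound 2 (0.24 log units; within the scatter) stays within the scatter.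

Compound 3 `COc1cc(-c2nn(-c3ccc(NC(=O)c4ccc(Cl)c(C(F)(F)F)c4)cc3)cc2-c2ccncc2)ccc1Cl` differs from compound 2 by trifluoromethyl in place of chloro on an aromatic carbon. Within the data shown here, no measured step touches this position; the single step of a 1.7-fold lower number from compound 1 to compound 2 (0.24 log units; within the scatter) concerns the carbonyl side and bears only indirectly. Nothing in the data points to a shift beyond the scatter in this assay, so the expected step of a 1.1-fold lower number from compound 2 to compound 3 (0.04 log units; within the scatter) is small. Compound 3 is estimated at 1500 nM, range 600 nM to 4000 nM.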

Compound 3, half-maximal inhibitory concentration: 1590 nM
Beside the measured number, compound 3's estimate is 1.1-fold (0.03 log units) below it; the measured number falls inside the stated range.
By their numbers in this assay, from the lowest: compounds 3, 2 and 1 (each within the scatter of the next).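

In this assay, among these compounds, trifluoromethyl in place of chloro on this aromatic carbon gives a 1.0-fold lower number from compound 2 to compound 3 (0.02 log units; within the scatter) and so leaves the number within the scatter, a change at this position that the earlier compounds did not cover. Changing the carbonyl substituent to 4-chloro-3-(trifluoromethyl)phenyl from (3,4-dichlorophenyl)amino gives a 1.8-fold lower number from compound 1 to compound 3 (0.25 log units; within the scatter) and also stays within the scatter. No supporting evidence bears on this result. Going by these compounds, whether an amine or a carboxylic acid on this aromatic carbon would move the number beyond the scatter remains open.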